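Changing the end group on the chain of compound 2

The source may hold more compounds than are shown below. What is called first, only, known or untested is meant among the compounds shown, and "the series" means these compounds.

Compound 2 `O=C(/C=C/c1cccc(Br)n1)Nc1ccc2ncnc(Nc3cccc(Cl)c3)c2c1`: 10700 nM
Compound 1 `Clc1cccc(Nc2ncnc3ccc(NCc4ncc5ccccc5n4)cc23)c1`: 5650 nM

In a functional assay on HepG2 cells (Homo sapiens) for antiproliferative activity, read by MTT assay, with a stated time of 48 h (on this read-out higher numbers stand for weaker inhibition and lower numbers for stronger inhibition), compound 2 gives 10700 nM, the highest of the two numbers; compound 1 gives 5650 nM, and the two lie within the usual scatter, so neither can be called the more potent. Compound 3 `O=C(/C=C/c1c[nH]c2ccccc12)Nc1ccc2ncnc(Nc3cccc(Cl)c3)c2c1` is compound 2 with 1H-indol-3-yl in place of 6-bromopyridin-2-yl on a double-bonded chain carbon bound to a double-bonded chain carbon. Among the measured compounds shown here, no measured pair shows what such a change does here, so the step from compound 2 to compound 3 is expected to be small, in no clear direction. Compound 3 is estimated at 7000 nM, with a range of 2000 nM to 25000 nM. The step of a 1.5-fold lower number from compound 2 to compound 3 (0.18 log units; within the scatter) is thus expected to stay near the scatter.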

Compound 3, half-maximal inhibitory concentration: 7020 nM
For compound 3 the middle estimate is 1.0-fold (0.00 log units) below the measured one; the measured number falls inside the stated range.
By their numbers in this assay, from the lowest: compounds 1, 3 and 2 (each within the scatter of the next).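

Among the compounds shown here, replacing 6-bromopyridin-2-yl with 1H-indol-3-yl gives, in this assay, a 1.5-fold lower number from compound 2 to compound 3 (0.18 log units; within the scatter) and is the first single-place change available here. At this end of the chain, a two-ring group with a hydrogen-bond donor and no bromine can therefore take the place of a one-ring group without a clear shift in the number. No measurement is available to explain this result. As far as these compounds go, whether an amine or a carboxylic acid at this place would move the number beyond the scatter remains open, as does the effect of a longer chain.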